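Replacing 2,3,6-trifluorophenyl with 2-chloro-4-fluorophenyl

A few compounds are considered here, and "the series" means these few. Any claim that something is new, unique, unknown or untested is made for them only; others in the source may bear on it.

In a functional assay on HOS cells (Homo sapiens) for antiproliferative activity, with a stated time of 72 h (a lower number here means a stronger inhibitor, a higher number a weaker inhibitor), compound 1 `OC[C@H]1O[C@@H](n2cnc3c(NCc4ccc(F)cc4)ncnc32)[C@H](O)[C@@H]1O` gives 13200 nM. Compound 2 `OC[C@H]1O[C@@H](n2cnc3c(NCc4ccccc4Br)ncnc32)[C@H](O)[C@@H]1O` gives > 166000 nM, which is a limit of the assay. Among the compounds with values here, the one measured step, an at least 12-fold higher number from compound 1 to compound 2 (1.09 log units; beyond the scatter), is large and beyond the scatter, with 2-bromophenyl in place of 4-fluorophenyl. Compound 3 `OC[C@H]1O[C@@H](n2cnc3c(NCc4c(F)ccc(F)c4F)ncnc32)[C@H](O)[C@@H]1O` stands without a number, its entry reading "not determined" (no result reported). Within the data shown here, compound 4 `OC[C@H]1O[C@@H](n2cnc3c(NCc4ccc(F)cc4Cl)ncnc32)[C@H](O)[C@@H]1O` differs from it by 2-chloro-4-fluorophenyl in place of 2,3,6-trifluorophenyl on a saturated chain carbon bound to a nitrogen on an aromatic ring, so no step can be counted from compound 3. The entering 2-chloro-4-fluorophenyl resembles both groups of the measured step, so compound 4 is expected to read higher in this assay than compound 1 at 13200 nM, by a smaller step than that one. Compound 4 is estimated at 55000 nM, within a range of 15000 nM to 170000 nM.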

Compound 4, half-maximal inhibitory concentration: > 166000 nM
Compound 4: only a limit was reported; the forecaster's own chance of this, stated with the estimate: 35%; at least 3.0-fold (0.47 log units) between middle value and limit.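

In this assay, within the data shown here, chloro in place of hydrogen on an aromatic carbon is the only change behind an at least 12-fold higher number from compound 1 to compound 4 (1.09 log units; beyond the scatter), so this position responds strongly even when the 4-fluorophenyl of compound 1 is kept. Compound 4 gives > 166000 nM, which is a limit of the assay and not a number. The step from compound 2 to compound 4 cannot be read, as both rest on the same limit: the limit of > 166000 nM in this assay, at which 2 of the 4 values shown sit.

As far as these compounds go, whether methoxy or an amine in place of the chloro would keep the reading near that of compound 1 stays open. So does the true potency of compound 2 and compound 4.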